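Second Fluoro on the Aryl Ring: Maximal Response Expected

This account rests on a few compounds, and the source may have more. Where it says the series, first, only, none or still open, it means among the compounds named here.

Measured compounds:
Compound 1 `CC(O[C@H]1CC[C@]2(CC1)COC(C)(C)C2)c1nc(-c2ccc(CS(C)(=O)=O)c(F)c2)no1` gives 130% in a functional assay on HEK293 cells for agonist activity at Glucose-dependent insulinotropic receptor (Homo sapiens), read by cAMP accumulation, with a stated time of 30 min; a lower number here means a smaller maximal response, a higher number a larger maximal response.
Compound 2 `C[C@@H](O[C@H]1CC[C@]2(CC1)COC(C)(C)C2)c1nc(-c2ccc(CS(C)(=O)=O)c(F)c2)no1` gives 106% in this assay.
Compound 3 `CC(O[C@H]1CC[C@]2(CC1)COC(C)(C)C2)c1nc(-c2ccc(CS(C)(=O)=O)cc2)no1` gives 120% in this assay.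

Compound 1 and compound 2 share the same atoms and bonds; the step of a number 24 percentage points lower from compound 1 to compound 2 (beyond the scatter) goes with the fact that one of compounds 1 and 2 is drawn with a defined configuration and the other without, at the place where they differ. From compound 3 to compound 1 the change is fluoro in place of hydrogen on an aromatic carbon, and the step it made was a number 10 percentage points higher from compound 3 to compound 1 (within the scatter). Compound 2 thus stands lowest of the three in this assay. The difference between the cores of compound 2 and compound 3 is not broken down here.

Compound 4 `C[C@@H](O[C@H]1CC[C@]2(CC1)COC(C)(C)C2)c1nc(-c2cc(F)c(CS(C)(=O)=O)c(F)c2)no1` is not yet measured. It differs from compound 2 by fluoro in place of hydrogen on an aromatic carbon. This is the same kind of change as from compound 3 to compound 1, but not the same: here the entering fluoro sits meta to a fluoro group as well as ortho to the (methylsulfonyl)methyl group. Because the earlier step of a number 10 percentage points higher from compound 3 to compound 1 (within the scatter) stayed within the scatter, compound 4 is expected to move by about a number 6 percentage points higher from compound 2 to compound 4 (within the scatter) in this assay. Compound 4 is therefore estimated at 112%, between 92% and 132%.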

Compound 4, largest response reached (reported as percent of maximum), in percent of the reference or control that the assay uses: 109%
Compound 4: middle estimate off by 3 percentage points, on the high side; low and high end bracket the measured number.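

In this assay, fluoro in place of hydrogen on an aromatic carbon, ortho to a (methylsulfonyl)methyl group and meta to a fluoro group, made a step that was a number 3 percentage points higher from compound 2 to compound 4 (within the scatter). Set beside the earlier case, the same change gives a matching result on the two cores: the same change on two cores in this assay, a number 10 percentage points higher (within the scatter) from compound 3 to compound 1 and a number 3 percentage points higher (within the scatter) from compound 2 to compound 4, 7 percentage points apart, within the scatter of two such steps. Neither step lies beyond the scatter, so the two pairs do not show that this fluoro alters the maximal response at all, and they offer no rule for cores beyond those of compounds 1, 2, 3 and 4.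

The compounds shown leave open how the maximal response would run if a chloro or a trifluoromethyl took the place of the entering fluoro, or if a carboxylic acid or an amine stood in place of the (methylsulfonyl)methyl group. They also leave open what the S configuration at the saturated chain carbon would give alongside compound 4.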